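Dichlorophenyl replaces difluorophenyl on the ring amine

The compounds below may be only part of what the source reports. "The series", "measured", "known", "first", "only" and "open" are said of these compounds alone.

Three compounds sharing one core were examined in a functional assay on CHO cells with adenosine receptor A1 (Homo sapiens) as the target, read by cAMP accumulation and immunoassay, with a stated time of 6 min, tested at 0.1 uM; a lower number here means a stronger effect, a higher number a weaker effect of the compound at the concentration tested. Compound 1 `Nc1scc(CN2CCN(c3cccc(Cl)c3Cl)CC2)c1C(=O)c1ccc(Cl)cc1` gives 3.2%; compound 2 `Nc1scc(CN2CCN(c3cccc(F)c3)CC2)c1C(=O)c1ccc(Cl)cc1` gives -37%; compound 3 `Nc1scc(CN2CCN(c3cc(F)cc(F)c3)CC2)c1C(=O)c1ccc(Cl)cc1` gives -5%. Compound 3 stands second highest of the three: its nearest neighbour is compound 1, and the gap a number 8.2 percentage points lower from compound 1 to compound 3 (within the scatter) lies within the scatter, whereas against compound 2 the gap a number 32 percentage points higher from compound 2 to compound 3 (beyond the scatter) is large and beyond the scatter. Compound 4 `Nc1scc(CN2CCN(c3cc(Cl)ccc3Cl)CC2)c1C(=O)c1ccc(Cl)cc1` differs from compound 3 in one place: 2,5-dichlorophenyl in place of 3,5-difluorophenyl on an amine nitrogen in a ring. Among the compounds with values here, two measured steps bear on this change. Exchanging a 2,3-dichlorophenyl for a 3,5-difluorophenyl gave a number 8.2 percentage points lower from compound 1 to compound 3 (within the scatter), a step within the scatter, while exchanging the same 2,3-dichlorophenyl for a 3-fluorophenyl gave a number 40.2 percentage points lower from compound 1 to compound 2 (beyond the scatter), a large step. Compound 4 again carries a dichlorophenyl, as 2,5-dichlorophenyl rather than 2,3-dichlorophenyl. Because compound 1 gives 3.2% and its difluoro counterpart compound 3 sits within the scatter of that number, the step of a number 5 percentage points higher from compound 3 to compound 4 (within the scatter) is expected to be small, with no clear direction beyond the scatter. Compound 4 is therefore estimated at 0%, within a range from -30% to 25%.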

Compound 4, a percentage reported as activity, at one concentration (the size of the read-out at that concentration, not a potency): -6.2%
Compound 4: middle estimate off by 6.2 percentage points, on the high side; low and high end bracket the measured number.
By their numbers in this assay, from the lowest: compound 2; then compounds 4, 3 and 1 (each within the scatter of the next).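

In this assay, the 2,5-dichlorophenyl on the ring amine nitrogen of the new compound cannot be told apart from the 3,5-difluorophenyl, with a number 1.2 percentage points lower from compound 3 to compound 4 (within the scatter), nor from the 2,3-dichlorophenyl, with a number 9.4 percentage points lower from compound 1 to compound 4 (within the scatter), so a third arrangement of two halogens at this place also gives no resolved change in the read-out. The 3-fluorophenyl of compound 2 is now set apart from all three groups carrying two halogens, and the new comparison adds a number 30.8 percentage points higher from compound 2 to compound 4 (beyond the scatter). No measurement available here accounts for why the group with a single fluorine stands apart from the others.

The compounds shown leave open whether the separation of compound 2 follows the number of halogens, the particular halogen or its place, a question that an unsubstituted phenyl, a 3-chlorophenyl or a 2,5-difluorophenyl on the same nitrogen could help to settle. They also leave open whether the three groups that cannot be told apart at this single concentration would still match in a full concentration series.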